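This account rests on a few compounds, and the source may have more. Where it says the series, first, only, none or still open, it means among the compounds named here.

Compound 3 `CC1CCCC(C(=O)N2CCc3nc(C#Cc4ccccc4)sc3C2)C1` is one of three measured compounds that share a core and differ only in the ring attached to a carbonyl carbon. In an assay on HEK293 cells for negative allosteric modulation of metabotropic glutamate receptor 5 (Homo sapiens), read by FLIPR, with a stated time of 1 h (on this read-out lower numbers stand for stronger inhibition and higher numbers for weaker inhibition), compound 3 gives > 10000 nM, which is a limit of the assay rather than a number. Compound 2 `CC1CC(C(=O)N2CCc3nc(C#Cc4ccccc4)sc3C2)C1` likewise gives only the limit > 10000 nM in this assay. Compound 1 `O=C(C1CC1)N1CCc2nc(C#Cc3ccccc3)sc2C1`, with cyclopropyl at that carbonyl carbon, gives 290 nM in this assay. The steps of an at least 34-fold higher number from compound 1 to compound 2 (1.53 log units; beyond the scatter) and an at least 34-fold higher number from compound 1 to compound 3 (1.53 log units; beyond the scatter) are both large losses, and both end at the limit of > 10000 nM in this assay, at which 2 of the 3 values shown sit. The step that the two limits leave unreadable from compound 2 to compound 3 cannot be sized.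

Compound 4 `O=C(N1CCCCC1)N1CCc2nc(C#Cc3ccccc3)sc2C1` carries the change (piperidin-1-yl in place of 3-methylcyclohexyl on a carbonyl carbon). Among the compounds with values here, it keeps a six-membered ring at the carbonyl carbon, so the only steps that bear on it are the two large losses from compound 1, while the step from compound 3 cannot be read. A weak value near the limit is therefore expected, so that compound 4 is estimated at 6000 nM, between 1500 nM and 20000 nM, with the expected step of an at least 1.6-fold lower number from compound 3 to compound 4 (0.22 log units; that floor lies within the scatter) left uncertain in direction.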

Compound 4, half-maximal inhibitory concentration: > 10000 nM
Compound 4: a limit, no number (the forecaster's own chance of this, stated with the estimate: 50%); middle value at least 1.6-fold (0.22 log units) from the limit.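

Compound 4 shows that the loss at this carbonyl carbon is not confined to rings of carbon only: with piperidin-1-yl, which has one hetero atom in its six-membered ring, the step is an at least 34-fold higher number from compound 1 to compound 4 (1.53 log units; beyond the scatter). In this assay compound 4 gives > 10000 nM, which is a limit of the assay and not a number. Of the groups shown at this place, only the cyclopropyl of compound 1 now gives a measured number: the limit of > 10000 nM in this assay, at which 3 of the 4 values shown sit.

The steps among compound 2, compound 3 and compound 4 cannot be read, so these three groups cannot be ranked against one another. Going by these compounds, it also stays open whether an unsubstituted cyclobutyl, an ethyl chain or a dimethylamino group at this carbonyl carbon would give a measured number.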